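Changing one side chain on a shared core

This account rests on a few compounds, and the source may have more. Where it says the series, first, only, none or still open, it means among the compounds named here.

Compound 1 `CCCc1nc2c(C)ccnc2n1Cc1ccc(-c2ccccc2C(=O)O)cc1`: 3.16 nM; 3.16 nM (2 entries)
Compound 2 `COCc1nc2c(C)ccnc2n1Cc1ccc(-c2ccccc2C(=O)O)cc1`: 79.4 nM

Among the measured compounds shown here, in a functional assay (aorta) with Oryctolagus cuniculus as the target (a lower number here means tighter binding, a higher number weaker binding), compound 2 gives 79.4 nM, the only number it has, and one further entry for it carries no single number. Two entries for compound 1 both give 3.16 nM; 3.16 nM (2 entries), so compound 2 reads clearly higher, which means weaker binding.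

Compound 3 `CCSc1nc2c(C)ccnc2n1Cc1ccc(-c2ccccc2C(=O)O)cc1` keeps the core of compound 2 and changes one group: ethylsulfanyl in place of methoxymethyl on an aromatic carbon. Ethylsulfanyl replaces methoxymethyl on an aromatic carbon, between two ring nitrogen atoms. For the measured compounds named here, no measured compound carries sulfur, so the guidance is thin. The expected move is downward, a 7.9-fold lower number from compound 2 to compound 3 (0.90 log units; beyond the scatter). This expectation leans on compound 1 at 3.16 nM; 3.16 nM (2 entries), whose propyl chain, like ethylsulfanyl, holds no oxygen. For compound 3 the estimate is 10 nM, with an expected range of 2.5 nM to 40 nM.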

Compound 3, dissociation constant: 5.01 nM
Estimate against measurement, compound 3: 2.0-fold (0.30 log units) above; the range from low to high includes it.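

In this assay, the change of the side chain that sits between two ring nitrogen atoms gives a 16-fold lower number from compound 2 to compound 3 (1.20 log units; beyond the scatter), although the two groups have the same counts of heavy atoms and hydrogen-bond acceptors. This position therefore responds strongly to a change that those counts do not capture. Compound 3 gives 5.01 nM and compound 1 gives 3.16 nM; 3.16 nM (2 entries), close values that show a chain carrying sulfur can read much like the propyl chain, while nothing shown gives a measured reason for the size of the step.

The compounds shown leave open how an ethoxy group, a methylsulfanyl group or a longer butyl chain would read at this position. They also leave open whether a similar step would appear on a different core.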